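From butyl to tert-butyl in a permeability series

The source may report more compounds than this note shows. Statements on the series, on what has been measured and on what is new or still open speak of the compounds shown alone.

Compounds measured in an ADME assay on Caco-2 cells (Homo sapiens) for permeability, read by LC-MS, in the apical to basolateral direction, with a stated time of 60 min, at pH 6.5; on this read-out higher numbers stand for higher permeability and lower numbers for lower permeability:
- compound 1 `CC(C)(C)[C@@H](O)C(=O)N1C[C@@H]2C[C@@H]2[C@H]1C(=O)NCc1cc(Cl)ccc1-n1cnnn1`: 17 10^-6 cm/s
- compound 2 `CCCC[C@@H](O)C(=O)N1C[C@H]2C[C@H]2[C@H]1C(=O)NCc1cc(Cl)ccc1-n1cnnn1`: 33 10^-6 cm/s
- compound 3 `CC(C)(C)[C@@H](O)C(=O)N1Cc2ccccc2[C@H]1C(=O)NCc1cc(Cl)ccc1-n1nnnn1`: 9 10^-6 cm/s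

In this assay compound 2 gives 33 10^-6 cm/s as its number. That lies within the usual scatter of compound 1 at 17 10^-6 cm/s and no order can be read between these two. Compound 3 at 9 10^-6 cm/s falls below compound 2 by more than the scatter.

Compound 4 `CC(C)(C)[C@@H](O)C(=O)N1C[C@H]2C[C@H]2[C@H]1C(=O)NCc1cc(Cl)ccc1-n1cnnn1` has not yet been measured. It carries tert-butyl in place of butyl on a saturated chain carbon bound to a carbonyl carbon and an oxygen on a saturated carbon and this is the change followed here. Within the data shown here, no pair of measured compounds shows this change on its own, which leaves the size of the step open. A modest fall in this assay is expected, perhaps none beyond the scatter. That expectation leans on compound 1, which also carries tert-butyl and gives 17 10^-6 cm/s as its number. The expected change is a 1.7-fold lower number from compound 2 to compound 4 (0.22 log units; within the scatter) and remains an estimate until it is tested. For compound 4 the estimated value is 20 10^-6 cm/s with an expected range from 10 10^-6 cm/s to 38 10^-6 cm/s in this measurement.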

Compound 4, apparent permeability: 3.8 10^-6 cm/s
Estimate against measurement, compound 4: 5.3-fold (0.72 log units) above, outside the stated range (below it).
By their numbers in this assay, from the lowest: compound 4; then compounds 3, 1 and 2 (each within the scatter of the next, the first and the last beyond it).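

In this assay, the change from butyl to tert-butyl on a saturated chain carbon bound to a carbonyl carbon and an oxygen on a saturated carbon now has a size of its own: the two groups have the same atoms, joined differently, and the change gives an 8.7-fold lower number from compound 2 to compound 4 (0.94 log units; beyond the scatter). Carrying tert-butyl does not by itself set the number in this series, as the two tert-butyl compounds that share this core are separated by a 4.5-fold lower number from compound 1 to compound 4 (0.65 log units; beyond the scatter). That second step can be assigned to configuration, because nothing else separates the pair: the fact that compounds 1 and 4 differ only in the configuration as drawn

The compounds shown leave open whether the change from butyl to tert-butyl would have the same size in the configuration drawn for compound 1, and so whether chain shape and configuration act independently or together at this position. They also leave open how a longer chain, a cyclohexyl group or an amine at this position would read in this assay.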